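Swapping a basic side chain for methylsulfonyl

The source may report more compounds than this note shows. Statements on the series, on what has been measured and on what is new or still open speak of the compounds shown alone.

Three compounds share one core and differ only in the group attached to one arm of the aniline ring. Compound 1 `C=CC(=O)Nc1cc(CCO)cc(C)c1Nc1ncc2cc(-c3c(Cl)c(OC)cc(OC)c3Cl)ccc2n1` carries a hydroxyethyl chain there, and in a functional assay on Huh-7 cells (Homo sapiens) for inhibition, read by sulforhodamine B assay, with a stated time of 72 h (a lower number here means a stronger inhibitor, a higher number a weaker inhibitor), compound 1 gives 2410 nM. Compound 2 `C=CC(=O)Nc1cc(CCCN(C)C)cc(C)c1Nc1ncc2cc(-c3c(Cl)c(OC)cc(OC)c3Cl)ccc2n1` carries a dimethylaminopropyl chain instead, and in this assay compound 2 gives 2240 nM. Compound 3 `C=CC(=O)Nc1cc(CCCN2CCCC2)cc(C)c1Nc1ncc2cc(-c3c(Cl)c(OC)cc(OC)c3Cl)ccc2n1` carries a pyrrolidinylpropyl chain, and in this assay compound 3 gives 4260 nM. Among the three numbers that of compound 3 is the largest, yet a 1.8-fold higher number from compound 1 to compound 3 (0.25 log units; within the scatter) and a 1.9-fold higher number from compound 2 to compound 3 (0.28 log units; within the scatter) both stay within the scatter, as does a 1.1-fold lower number from compound 1 to compound 2 (0.03 log units; within the scatter), so the three cannot be told apart.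

Compound 4 `C=CC(=O)Nc1cc(S(C)(=O)=O)cc(C)c1Nc1ncc2cc(-c3c(Cl)c(OC)cc(OC)c3Cl)ccc2n1` takes the step (methylsulfonyl in place of 3-(pyrrolidin-1-yl)propyl on an aromatic carbon). Among the compounds with values here, no measured step removes the chain or brings in a group of this kind; the measured steps only show that the hydroxy, dimethylamino and pyrrolidinyl chains give numbers within the scatter of each other. The expectation is therefore a step of about a 1.4-fold lower number from compound 3 to compound 4 (0.15 log units; within the scatter) in this assay, that is, none beyond the scatter. Compound 4 is estimated at 3000 nM, within a range from 800 nM to 12000 nM.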

Compound 4, half-maximal inhibitory concentration: 1940 nM
For compound 4 the middle estimate is 1.5-fold (0.19 log units) above the measured one, within the range that was stated.
By their numbers in this assay, from the lowest: compounds 4, 2, 1 and 3 (each within the scatter of the next, the first and the last beyond it).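

In this assay, the position tolerates a very different group: the 3-(pyrrolidin-1-yl)propyl chain of 8 heavy atoms, with its ring, gives way to methylsulfonyl of 4 heavy atoms and no ring, and the compound stays in the same range. The change gives a 2.2-fold lower number from compound 3 to compound 4 (0.34 log units; beyond the scatter), a modest step and the only one of the three that clears the scatter, while a 1.2-fold lower number from compound 2 to compound 4 (0.06 log units; within the scatter) and a 1.2-fold lower number from compound 1 to compound 4 (0.09 log units; within the scatter) do not, so methylsulfonyl separates from one chain only and shows no general edge over chains here. Nothing shown explains that single step.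

Still open, on these data alone, is whether a carboxylic acid, a primary amine or a longer sulfonyl group such as ethylsulfonyl would separate from these four compounds. Also open, as far as these compounds go, is whether any group at this position can produce more than a modest step.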